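Swapping a Saturated Amine Arm for an Indoline Ring

A few compounds are considered here, and "the series" means these few. Any claim that something is new, unique, unknown or untested is made for them only; others in the source may bear on it.

Measured compounds:
Compound 1, `COc1ccc2[nH]c(C(=O)N3CC(=O)N(Cc4ccccc4)[C@@H](CN4CCC(C)CC4)C3)cc2c1`: 93100 nM
Compound 2, `COc1cccc(CN2C(=O)CN(C(=O)c3cc4cc(OC)ccc4[nH]3)C[C@@H]2CCc2ccccc2)c1`: 5100 nM

In a physicochemical assay for solubility, read by spectrophotometry, in phosphate buffer, with a stated time of 2 h, at pH 7.4 (a higher number here means a more soluble compound, a lower number a less soluble compound), compound 1 gives 93100 nM, the higher of the two numbers seen so far. Compound 2, which shares the core but carries different groups, gives 5100 nM in this assay; the gap between the two lies beyond the usual scatter, so compound 1 is the more soluble of the pair on these numbers.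

Compound 3, `COc1ccc2[nH]c(C(=O)N3CC(=O)N(Cc4ccccc4)[C@@H](N4CCc5ccccc54)C3)cc2c1`, has not yet been measured. It differs from compound 1 in one place: 2,3-dihydro-1H-indol-1-yl in place of (4-methylpiperidin-1-yl)methyl on a saturated ring carbon. Among the measured compounds shown here, no measured pair shows exactly this change, so the expectation rests on the size and direction of the structural swap alone. A step from compound 1 to compound 3 of a 12-fold lower number from compound 1 to compound 3 (1.07 log units; beyond the scatter) in this assay is expected, downward. Compound 3 is therefore estimated at 8000 nM in this assay, within a range of 2000 nM to 30000 nM.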

Compound 3, solubility: 7000 nM
Estimate against measurement, compound 3: 1.1-fold (0.06 log units) above; measured number inside the range.
By their numbers in this assay, from the lowest: compounds 2 and 3 (each within the scatter of the next); then compound 1.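

In this assay, putting 2,3-dihydro-1H-indol-1-yl in place of (4-methylpiperidin-1-yl)methyl on this saturated ring carbon brings a 13-fold lower number from compound 1 to compound 3 (1.12 log units; beyond the scatter), so the group at this position of the shared core can move the number by a large step. The two groups have the same computed counts of hydrogen-bond donors and acceptors and no net charge, so those counts do not separate them; they differ in their rings, with a six-membered non-aromatic ring leaving and a five-membered non-aromatic ring plus a six-membered aromatic ring entering. No measured evidence here bears on what lies behind the drop.

As far as these compounds go, whether the step follows the aromatic ring or the loss of the one-carbon link remains open. A piperidin-1-yl group set directly on this carbon would help separate the two, and a single step supports no trend at this position.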